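Swapping 3-fluorophenyl for furan-2-yl: an expected small step

The source may report more compounds than this note shows. Statements on the series, on what has been measured and on what is new or still open speak of the compounds shown alone.

Of the compounds shown here, three sharing one core have been tested in a functional assay on K562 cells (Homo sapiens) for inhibition, with a stated time of 72 h; on this read-out lower numbers stand for stronger inhibition and higher numbers for weaker inhibition. Compound 1 `NC1CCC(Nc2nc(NCc3ccc(Br)cc3)c3ncn(C4CCCC4)c3n2)CC1`, which carries a bromo group, gives 1170 nM. Compound 2 `COc1ccccc1-c1ccc(CNc2nc(NC3CCC(N)CC3)nc3c2ncn3C2CCCC2)cc1`, with 2-methoxyphenyl in that place, gives 347 nM. Compound 3 `NC1CCC(Nc2nc(NCc3ccc(-c4cccc(F)c4)cc3)c3ncn(C4CCCC4)c3n2)CC1`, with 3-fluorophenyl there, gives 290 nM. Compound 3 therefore sits level with compound 2 within the scatter, and both lie lower than compound 1 by more than the scatter.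

Compound 4 `NC1CCC(Nc2nc(NCc3ccc(-c4ccco4)cc3)c3ncn(C4CCCC4)c3n2)CC1` has furan-2-yl in place of 3-fluorophenyl on an aromatic carbon. For the measured compounds named here, the closest precedent is the exchange of one aromatic ring for another, a 1.2-fold lower number from compound 2 to compound 3 (0.08 log units; within the scatter), which stayed within the scatter. The modest steps of a 3.4-fold lower number from compound 1 to compound 2 (0.53 log units; beyond the scatter) and a 4.0-fold lower number from compound 1 to compound 3 (0.61 log units; beyond the scatter) both replaced bromo with a ring, and compound 4 keeps a ring in this place. However, no measured compound has a five-membered ring there, so the expectation stays uncertain. The estimated change is a 1.0-fold higher number from compound 3 to compound 4 (0.01 log units; within the scatter), and no step beyond the scatter is expected. In this assay, compound 4 is estimated at 300 nM, with an expected range from 120 nM to 750 nM.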

Compound 4, half-maximal inhibitory concentration: 96 nM
Compound 4: the middle estimate sits 3.1-fold (0.49 log units) above what was measured; the measured number lies below the stated range.
By their numbers in this assay, from the lowest: compound 4; then compounds 3 and 2 (each within the scatter of the next); then compound 1.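

In this assay, for the compounds shown here, the identity of the ring at this position matters more than the earlier compounds suggested: compounds 2 and 3 sat level within the scatter, yet furan-2-yl stands apart from both, giving a 3.0-fold lower number from compound 3 to compound 4 (0.48 log units; beyond the scatter) and a 3.6-fold lower number from compound 2 to compound 4 (0.56 log units; beyond the scatter) as its steps. Having a ring in place of bromo is therefore not the whole story, since the step with furan-2-yl reaches a 12-fold lower number from compound 1 to compound 4 (1.09 log units; beyond the scatter) and so goes well past what the two six-membered rings gave over bromo. No measurement at hand explains why this ring gives the lowest number of the four.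

Compound 4 differs from compound 3 in both ring size and the presence of an oxygen atom, so the compounds shown leave open which of these two differences goes with the lower number. Thiophen-2-yl, with sulfur where furan-2-yl has oxygen, and pyridin-3-yl, a six-membered ring containing nitrogen, would help pull these two differences apart.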